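The source may report more compounds than this note shows. Statements on the series, on what has been measured and on what is new or still open speak of the compounds shown alone.

Working notes on the series. All compounds share one core carrying a 2-hydroxyethoxymethyl chain on a ring nitrogen. Compound 1 `O=c1ccn(COCCO)c(=O)[nH]1` is the unsubstituted parent. In a functional assay on L1210 cells (Mus musculus) for inhibition (on this read-out higher numbers stand for weaker inhibition and lower numbers for stronger inhibition), compound 1 gives only a limit of the assay, > 1000 ug/mL. Compound 2 `O=c1[nH]c(=O)n(COCCO)cc1[N+](=O)[O-]` carries a nitro group on an aromatic carbon. In this assay compound 2 likewise gives only a limit, > 1000 ug/mL. Compound 3 `O=c1[nH]c(=O)n(COCCO)cc1/C=C/Br` carries a 2-bromoethenyl group on an aromatic carbon. In this assay compound 3 also gives only a limit, > 1000 ug/mL. The steps among these three, a step that the two limits leave unreadable from compound 1 to compound 2, a step that the two limits leave unreadable from compound 1 to compound 3 and a step that the two limits leave unreadable from compound 2 to compound 3, therefore have no readable size, since every value sits at the same point, (the limit of > 1000 ug/mL in this assay, at which 3 of the 3 values shown sit). Compound 4 `CC(=O)OCCOCn1cc(/C=C/Br)c(=O)[nH]c1=O` differs from compound 3 as follows: acetyl in place of hydrogen on an oxygen on a saturated carbon. Among the compounds with values here, no measured step touches this oxygen, and nothing shows a value inside the measurable range, so no direction can be read for the change. Compound 4 is expected to stay at the limit as well, which means an estimated step that the limit leaves unreadable from compound 3 to compound 4. The estimate for compound 4 is 1500 ug/mL, with a range from 500 ug/mL to 5000 ug/mL.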

Compound 4, concentration for 50% inhibition: > 1000 ug/mL
Compound 4: only a limit was reported (the forecaster's own chance of this, stated with the estimate: 85%); the middle value is on the limit's open side.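

No step can be read between compound 3 and compound 4 in this assay, since both sit at the same limit of the assay: the limit of > 1000 ug/mL in this assay, at which 4 of the 4 values shown sit.

The compounds shown leave open whether any change on the shared core brings a value inside the measurable range.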